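Removing a Hydroxy From the Aromatic Ring of Compound 1

This account rests on a few compounds, and the source may have more. Where it says the series, first, only, none or still open, it means among the compounds named here.

Compound 1 `C=CCSC[C@H](NC(=O)c1cc(O)c(O)c(O)c1)C(=O)OC` is the starting point of this step. In an assay on RAW264.7 cells for antagonist activity at Toll-like receptor 2 (Mus musculus), read by Griess assay, with a stated time of 24 h (a higher number here means a weaker inhibitor, a lower number a stronger inhibitor), compound 1 gives 52100 nM, the highest of the three numbers recorded, though its nearest neighbour compound 3 `COC(=O)[C@H](CSCc1ccc(F)cc1)NC(=O)c1cc(O)c(O)c(O)c1` gives 50200 nM and compound 2 `C=CCCCSC[C@H](NC(=O)c1cc(O)c(O)c(O)c1)C(=O)OC` gives 39200 nM, so all three sit together. The recorded steps, a 1.3-fold lower number from compound 1 to compound 2 (0.12 log units; within the scatter) and a 1.0-fold lower number from compound 1 to compound 3 (0.02 log units; within the scatter), both change the group on the saturated chain carbon bound to sulfur and both lie within the scatter. Compound 4 `C=CCSC[C@H](NC(=O)c1cc(O)cc(O)c1)C(=O)OC` differs from compound 1 elsewhere: hydrogen in place of hydroxy on an aromatic carbon, the hydroxy that leaves being the one ortho to two hydroxy groups and para to a large group. Going by the values given here, no measured step touches this part of the shared core, so nothing among the three compounds tells the direction or size of the change. The expectation for compound 4 therefore rests on compound 1 alone, with a wide range and a step of a 1.5-fold higher number from compound 1 to compound 4 (0.19 log units; within the scatter) in this assay. Compound 4 is estimated at 80000 nM, between 30000 nM and 250000 nM.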

Compound 4, half-maximal inhibitory concentration: 58500 nM
Beside the measured number, compound 4's estimate is 1.4-fold (0.14 log units) above it; measured number inside the range.
By their numbers in this assay, from the lowest: compounds 2, 3, 1 and 4 (each within the scatter of the next).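

Going by these compounds alone, replacing the hydroxy with hydrogen on the aromatic carbon, at the place ortho to two hydroxy groups and para to a large group, gives in this assay a 1.1-fold higher number from compound 1 to compound 4 (0.05 log units; within the scatter), the only measured step at the aromatic ring of the shared core. With the rest of compound 1 kept, this hydroxy can therefore be lost without a change that this assay can distinguish from the scatter. Nothing available gives a reason for this result.

From the compounds shown here alone, whether a methoxy or an amine at this place would behave the same remains open, as does the effect of removing either of the other hydroxy groups. Also open, going by these compounds, is whether this replacement would give the same small step with the but-3-en-1-yl or 4-fluorophenyl groups of compound 2 and compound 3.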